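A carbon ring gives way to a trimethyl group

The source may hold more compounds than are shown below. What is called first, only, known or untested is meant among the compounds shown, and "the series" means these compounds.

- compound 1 `Cc1cc(N2C(=O)CNC2=O)cc(C)c1CCS(=O)(=O)N1CCC2(CC1)N=C(c1ccc(OC(F)(F)F)cc1)NC2=O` gives 110 mL.min-1.g-1
- compound 2 `Cc1cc(N2C(=O)NC(=O)C23CCCC3)cc(C)c1CCS(=O)(=O)N1CCC2(CC1)N=C(c1ccc(OC(F)(F)F)cc1)NC2=O` gives 35 mL.min-1.g-1

In an ADME assay on microsomes from liver (Homo sapiens) for pharmacokinetics, read by LC-MS, using NADPH, with a stated time of 30 min, tested at 1 uM (on this read-out higher numbers stand for fast clearance and lower numbers for slow clearance), compound 2 holds the lower of the two numbers, 35 mL.min-1.g-1. Compound 3 `Cc1cc(N2C(=O)N(C)C(=O)C2(C)C)cc(C)c1CCS(=O)(=O)N1CCC2(CC1)N=C(c1ccc(OC(F)(F)F)cc1)NC2=O` keeps the shared core and changes one group on the aromatic carbon: a group of 10 heavy atoms (6 carbon, 2 nitrogen, 2 oxygen; one five-membered non-aromatic ring with 2 hetero atoms) in place of a group of 11 heavy atoms (7 carbon, 2 nitrogen, 2 oxygen; one five-membered non-aromatic ring of carbon only, one five-membered non-aromatic ring with 2 hetero atoms), on an aromatic carbon. The incoming 3,5,5-trimethyl-2,4-dioxoimidazolidin-1-yl group has no five-membered ring of carbon only. Within the data shown here, one measured step bears on this change: a 3.1-fold lower number from compound 1 to compound 2 (0.50 log units; beyond the scatter), a modest drop that came with the larger group gaining that carbon ring. Compound 3 loses the ring but keeps a group close in size to that of compound 2, so only part of that drop is expected to be given back. The expected change is small and probably within the scatter: a 1.3-fold higher number from compound 2 to compound 3 (0.11 log units; within the scatter). For compound 3 the estimated value is 45 mL.min-1.g-1, with an expected range of 20 mL.min-1.g-1 to 100 mL.min-1.g-1.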

Compound 3, intrinsic clearance in microsomes: 330 mL.min-1.g-1
Compound 3: middle estimate off by 7.3-fold (0.87 log units), on the low side, and the stated range ends below it.
By their numbers in this assay, from the lowest: compound 2; then compound 1; then compound 3.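

In this assay, this position proves far more sensitive than the earlier step suggested: swapping the group of compound 2 for 3,5,5-trimethyl-2,4-dioxoimidazolidin-1-yl gives a 9.4-fold higher number from compound 2 to compound 3 (0.97 log units; beyond the scatter). Group size alone does not set the direction, since compound 2 and compound 3 both carry a larger group than compound 1, yet the first step is a 3.1-fold lower number from compound 1 to compound 2 (0.50 log units; beyond the scatter) and the other is a 3.0-fold higher number from compound 1 to compound 3 (0.48 log units; beyond the scatter). The step from compound 2 to compound 3 also removes the carbon-only ring and the hydrogen-bond donor together, so these two changes cannot be told apart here.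

Nothing measured here explains why clearance moves this way. Also open, as far as these compounds go, is whether a group that keeps the carbon-only ring but carries a methyl or an ethyl group in place of the donor hydrogen would stay low or climb.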